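Shifting the Chlorine on the Phenyl of Compound 3

The compounds below may be only part of what the source reports. "The series", "measured", "known", "first", "only" and "open" are said of these compounds alone.

Compound 1: `CCCCCCCCc1ccc(OCC(=O)Cn2nnc(C)n2)cc1`; in an assay on microsomes from brain for inhibition of Fatty-acid amide hydrolase 1 (Rattus norvegicus), read by fluorescence and HPLC, with a stated time of 60 min (a lower number here means a stronger inhibitor, a higher number a weaker inhibitor), compound 1 gives 27 nM.
Compound 2: `CCCCCCCCc1ccc(OCC(=O)Cn2nnc(-c3ccccc3)n2)cc1`; in this assay compound 2 gives 24 nM.
Compound 3: `CCCCCCCCc1ccc(OCC(=O)Cn2nnc(-c3ccc(Cl)cc3)n2)cc1`; in this assay compound 3 gives 35 nM.

Compound 3 carries the highest of the three numbers, yet it is not separated from its neighbours by more than the scatter: the step of a 1.3-fold higher number from compound 1 to compound 3 (0.11 log units; within the scatter) and the step of a 1.5-fold higher number from compound 2 to compound 3 (0.16 log units; within the scatter) are both small, and so is a 1.1-fold lower number from compound 1 to compound 2 (0.05 log units; within the scatter). Across the three compounds, whether the aromatic carbon bears methyl, phenyl or 4-chlorophenyl, the read-out hardly moves.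

Compound 4, `CCCCCCCCc1ccc(OCC(=O)Cn2nnc(-c3cccc(Cl)c3)n2)cc1`, differs from compound 3 only in the change (3-chlorophenyl in place of 4-chlorophenyl on an aromatic carbon). Within the data shown here, no measured step moves a chlorine from one position of the phenyl to another, so the nearest guidance comes from the steps that replace the whole group on that carbon, and every one of those stayed within the scatter. Compound 4 is therefore expected to show no step beyond the scatter in this assay, with a 1.2-fold lower number from compound 3 to compound 4 (0.07 log units; within the scatter) as the estimated change. For compound 4 the expected value is 30 nM, with a range from 12 nM to 80 nM.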

Compound 4, half-maximal inhibitory concentration: 24 nM
The estimate for compound 4 lay 1.3-fold (0.10 log units) above the measured number; low and high end bracket the measured number.
By their numbers in this assay, from the lowest: compounds 2, 4, 1 and 3 (each within the scatter of the next).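

In this assay the chlorine on the phenyl is now moved directly, and 3-chlorophenyl in place of 4-chlorophenyl gives a 1.5-fold lower number from compound 3 to compound 4 (0.16 log units; within the scatter) so that shifting the chlorine on this group, which sits on the aromatic carbon between two ring nitrogen atoms, leaves no step beyond the scatter. The 3-chlorophenyl group also reads the same as the groups it can be set against, with no change at the digits printed from compound 2 to compound 4 (within the scatter) for chloro in place of hydrogen and a 1.1-fold lower number from compound 1 to compound 4 (0.05 log units; within the scatter) for 3-chlorophenyl in place of methyl, and so methyl, phenyl and both chlorophenyl groups on this carbon cannot be told apart in this assay. Nothing at hand accounts for this flat response at the position.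

The compounds shown leave open whether an amine or a carboxylic acid on the phenyl would stay as close to these numbers as chlorine does. They also leave open whether any group on this carbon can produce a step beyond the scatter, since every group seen here stays within it.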